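Shorter, branched side chain on the hydroxy pyranone core

The source may hold more compounds than are shown below. What is called first, only, known or untested is meant among the compounds shown, and "the series" means these compounds.

Measured compounds:
- compound 1 `CCCCCCCc1coc(=O)c(C)c1O` gives 2200000 nM in an ADME assay on MDCK cells (Canis lupus familiaris) for cytotoxicity, read by crystal violet staining, with a stated time of 48 h; on this read-out lower numbers stand for higher toxicity in this test and higher numbers for lower toxicity in this test
- compound 2 `COc1c(CCCCC(C)C)coc(=O)c1C` gives 1880000 nM
- compound 3 `CCCCCCCc1coc(=O)c(C)c1OC` gives 2230000 nM

Compound 1 stands second highest of the three numbers, with the step of a 1.0-fold higher number from compound 1 to compound 3 (0.01 log units; within the scatter) and the step of a 1.2-fold higher number from compound 2 to compound 3 (0.07 log units; within the scatter) both within the scatter; the three compounds are indistinguishable on this read-out. Compound 4 `Cc1c(O)c(CCCC(C)C)coc1=O` differs from compound 1 in one place: isopropyl in place of butyl on a saturated chain carbon, three bonds along the chain from an aromatic carbon. Going by the values given here, the only step of a related kind, a 1.2-fold higher number from compound 2 to compound 3 (0.07 log units; within the scatter), changed the branching of the chain and stayed within the scatter, and the change a 1.0-fold higher number from compound 1 to compound 3 (0.01 log units; within the scatter) on the ring oxygen likewise did nothing. No step beyond the scatter is therefore expected in this assay, in either direction. Compound 4 is estimated at 2100000 nM, with a range from 1000000 nM to 4400000 nM, meaning an expected step of a 1.0-fold lower number from compound 1 to compound 4 (0.02 log units; within the scatter).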

Compound 4, half-maximal cytotoxic concentration: 1240000 nM
Beside the measured number, compound 4's estimate is 1.7-fold (0.23 log units) above it, and the stated range covers the measured number.
By their numbers in this assay, from the lowest: compounds 4, 2, 1 and 3 (each within the scatter of the next).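

In this assay the swap of butyl for isopropyl, on a saturated chain carbon three bonds along the chain from an aromatic carbon, gives a 1.8-fold lower number from compound 1 to compound 4 (0.25 log units; within the scatter) and so does not separate compound 4 from compound 1. Like the earlier steps, this one stays within the scatter, now with a chain that has one carbon fewer and a branched end. Nothing available explains the number.

Going by these compounds, whether a much longer chain, or a chain ending in an amine or a carboxylic acid, would give a step beyond the scatter remains open.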